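The source may report more compounds than this note shows. Statements on the series, on what has been measured and on what is new or still open speak of the compounds shown alone.

Measured compounds:
compound 1 `COc1cccc(N2C(=O)/C(=C/c3cc(C)n(-c4cccc(-c5nnn[nH]5)c4)c3C)SC2=S)c1` with 40600 nM
compound 2 `Cc1cc(/C=C2\SC(=S)N(c3ccc(O)cc3)C2=O)c(C)n1-c1cccc(-c2nnn[nH]2)c1` with 45600 nM

In an ADME assay on MT2 cells (Homo sapiens) for cytotoxicity, read by XTT assay, with a stated time of 4 days (a higher number here means that more compound is tolerated, a lower number that less compound is tolerated), compound 1 gives the lowest of the two numbers, and its nearest neighbour is compound 2, which gives 45600 nM; the gap between the two is within the scatter, so neither can be called better tolerated than the other. For the measured compounds named here, the one measured step, a 1.1-fold higher number from compound 1 to compound 2 (0.05 log units; within the scatter), exchanges the group on the ring nitrogen of the shared core and changes the number by less than repeated measurements usually differ.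

The compound still to be measured is compound 3 `Cc1cc(/C=C2\SC(=S)N(c3ccc(Br)cc3)C2=O)c(C)n1-c1cccc(-c2nnn[nH]2)c1`. Its change from compound 1 is 4-bromophenyl in place of 3-methoxyphenyl on an amide-type nitrogen in a ring. The step from compound 1 to compound 2 is the only one that bears on it, since it alters the same group at the same place on the ring nitrogen; that step was within the scatter. Going by the values given here, no measured step shows what a bromine-bearing ring does here, so the expectation for compound 3 rests on the small size of that one step. The account therefore expects no step beyond the scatter in this assay, in either direction, and the estimated step from compound 1 to compound 3 is a 1.0-fold lower number from compound 1 to compound 3 (0.01 log units; within the scatter). For compound 3 the estimated value in this assay is 40000 nM, with a range from 20000 nM to 80000 nM.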

Compound 3, half-maximal cytotoxic concentration: 46800 nM
Beside the measured number, compound 3's estimate is 1.2-fold (0.07 log units) below it; measured number inside the range.
By their numbers in this assay, from the lowest: compounds 1, 2 and 3 (each within the scatter of the next).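

In this assay the result extends the picture at this place, on an amide-type nitrogen in a ring, to a group carrying a halogen: a 1.2-fold higher number from compound 1 to compound 3 (0.06 log units; within the scatter) shows that 4-bromophenyl in place of 3-methoxyphenyl cannot be told apart from the starting compound. For the compounds shown here, the second comparison, a 1.0-fold higher number from compound 2 to compound 3 (0.01 log units; within the scatter) for bromo in place of hydroxy on an aromatic carbon, shows the same at the level of a single atom on the ring, so 3-methoxyphenyl, 4-hydroxyphenyl and 4-bromophenyl all stand level here, whereas the earlier pair had covered only two of these groups. No measurement at hand offers any explanation for this flat result.

The three compounds all keep a substituted phenyl ring at this place, so they leave open whether the number would stay level with a carboxylic acid or an amine on that ring, or with a longer alkyl chain in place of the ring. They also leave open whether the bromine would give the same number on another carbon of the phenyl ring, as in 3-bromophenyl.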